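A Benzyl Swap Without a Starting Number

A few compounds are considered here, and "the series" means these few. Any claim that something is new, unique, unknown or untested is made for them only; others in the source may bear on it.

Compound 1 `CCc1nc2c(C)cc(-c3ccc(CN4CCC[C@H]4CO)cc3)cn2c1NC(=O)OCc1cc(Cl)cc(Cl)c1` is the reference point here, yet it offers no number to start from. In a functional assay on Hep 3B2 cells (Homo sapiens) for inhibition, read by MTT assay, with a stated time of 72 h (a lower number here means a stronger inhibitor, a higher number a weaker inhibitor), compound 1 carries the entry "nd" (no result reported) and so has no measured strength. The only other tested relative is compound 2 `CCc1nc2c(C)cc(-c3ccc(CNCCO)cc3)cn2c1NC(=O)OCc1cc(Cl)cc(Cl)c1` in this small set. In this assay compound 2 gives > 20000 nM as its result, and this is a limit of the assay, not a number.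

Compound 3 `CCc1nc2c(C)cc(-c3ccc(CN4CCC[C@H]4CO)cc3)cn2c1NC(=O)OCc1ccc(F)cc1` changes one end of the molecule. The step 4-fluorophenyl in place of 3,5-dichlorophenyl on a saturated chain carbon bound to an oxygen next to a carbonyl group puts 4-fluorophenyl in place of 3,5-dichlorophenyl on a saturated chain carbon bound to an oxygen next to a carbonyl group. For the measured compounds named here, no measured pair shows what this exchange does, and the true position of compound 1 is unknown. The working expectation is therefore no step beyond the usual scatter in this assay in either direction, and this expectation is only loosely grounded. For compound 3 the estimated half-maximal inhibitory concentration is 6000 nM as a central figure, with 800 nM to 20000 nM as the expected range.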

Compound 3, half-maximal inhibitory concentration: > 20000 nM
Compound 3 was reported as a limit; the forecaster's own chance of this, stated with the estimate: 35%; at least 3.3-fold (0.52 log units) between middle value and limit.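

In this assay compound 3 gives > 20000 nM, which is a limit of the assay and not a number. For the compounds shown here, compound 1 has no reported result, so no step between compound 1 and compound 3 can be read. What 4-fluorobenzyl in place of 3,5-dichlorobenzyl does to inhibitory strength stays open, with the results shown gathered at one point: the limit of > 20000 nM in this assay, at which 2 of the 3 values shown sit.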